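The source may report more compounds than this note shows. Statements on the series, on what has been measured and on what is new or still open speak of the compounds shown alone.

Series notes. Compound 1 `COc1ccc(/C=C2\CN(Cc3cn(Cc4cccc(Cl)c4)nn3)C/C(=C\c3ccc(OC)cc3)C2=O)cc1` and compound 3 `COc1ccc(/C=C2\CN(C(=S)SCc3cn(Cc4cccc(Cl)c4)nn3)C/C(=C\c3ccc(OC)cc3)C2=O)cc1` both carry the 3-chlorobenzyl group but differ in the link between that group and the core; that difference is not broken down here. In a functional assay on MDA-MB-231 cells (Homo sapiens) for cytotoxicity, read by MTT assay, with a stated time of 24 h (a lower number here means a stronger inhibitor, a higher number a weaker inhibitor), compound 1 gives 98000 nM. In this assay compound 3 gives 32000 nM, the lower of the two measured numbers. Compound 2 `COc1ccc(/C=C2\CN(C(=S)SCc3cn(Cc4ccc(F)cc4)nn3)C/C(=C\c3ccc(OC)cc3)C2=O)cc1` arises from compound 3 by the change (4-fluorophenyl in place of 3-chlorophenyl on a saturated chain carbon bound to an aromatic nitrogen). For compound 2 this assay reports only a limit, > 100000 nM. The resulting step is an at least 3.1-fold higher number from compound 3 to compound 2 (0.49 log units; beyond the scatter), its size bounded by the limit of > 100000 nM in this assay, at which 1 of the 3 values shown sits.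

Compound 4 `COc1ccc(/C=C2\CN(Cc3cn(Cc4ccc(F)cc4)nn3)C/C(=C\c3ccc(OC)cc3)C2=O)cc1` carries the same change made on compound 1: 4-fluorophenyl in place of 3-chlorophenyl on a saturated chain carbon bound to an aromatic nitrogen. The change sits in the same place in both pairs, so it counts as the same kind of change. Compound 1 already stands at the higher measured number, so compound 4 is expected to move by a 2.6-fold higher number from compound 1 to compound 4 (0.41 log units; beyond the scatter), carried past the point where this assay stops reporting a number, if the change runs as it did before. Compound 4 is therefore estimated at 250000 nM, between 90000 nM and 600000 nM, most likely reported only as a limit.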

Compound 4, half-maximal inhibitory concentration: 70700 nM
Beside the measured number, compound 4's estimate is 3.5-fold (0.55 log units) above it; the whole stated range lies above it.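

In this assay, 4-fluorobenzyl in place of 3-chlorobenzyl gives a 1.4-fold lower number from compound 1 to compound 4 (0.14 log units; within the scatter), so on the core of compound 1 the change moves the number no further than the scatter, and its effect does not carry over from the other core: the same change on two cores in this assay, an at least 3.1-fold higher number (0.49 log units; beyond the scatter) from compound 3 to compound 2 and a 1.4-fold lower number (0.14 log units; within the scatter) from compound 1 to compound 4, at least 4.3-fold (0.63 log units) apart, beyond the scatter of two such steps. On these data alone, compound 2 stands at a limit and not at a number, so the step to it has only a bound and its full size stays unknown: the limit of > 100000 nM in this assay, at which 1 of the 4 values shown sits. Within the data shown here, these two pairs show only that the step differs between these two cores; they do not show which difference between the cores is responsible, and they give no rule for a further core.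

Each pair swaps the halogen and its place on the ring together, so the compounds shown do not separate the two. Also open, as far as these compounds go, is how either core responds to an unsubstituted benzyl group, or to an amine or a carboxylic acid on that ring.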